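Nitro for Hydroxy: Expected Effect on Cell Growth Inhibition

The source may hold more compounds than are shown below. What is called first, only, known or untested is meant among the compounds shown, and "the series" means these compounds.

Compound 1 `COc1ccc(/C(F)=C/c2cc(OC)c(OC)c(OC)c2)cc1O` carries a hydroxy group on its core; in a functional assay on cells (Endothelial cell, Bos taurus) for antiproliferative activity (a higher number here means a weaker inhibitor, a lower number a stronger inhibitor), compound 1 gives 26600 nM. Compound 2 `COc1ccc(/C(F)=C/c2cc(OC)c(OC)c(OC)c2)cc1[N+](=O)[O-]` differs from it by nitro in place of hydroxy on an aromatic carbon. In this assay compound 2 reaches only > 3000000 nM, which is a limit of the measurement and not a number. The resulting step is an at least 110-fold higher number from compound 1 to compound 2 (2.05 log units; beyond the scatter), and its size is bounded by the limit of > 3000000 nM in this assay, at which 1 of the 3 values shown sits. Compound 3 `COc1ccc(/C(F)=C(/F)c2cc(OC)c(OC)c(OC)c2)cc1O` has a different core; how that core differs from the core of compound 1 is not broken down here. In this assay compound 3 gives 4600 nM. Compound 4 `COc1ccc(/C(F)=C(/F)c2cc(OC)c(OC)c(OC)c2)cc1[N+](=O)[O-]` has not yet been measured and differs from compound 3 by nitro in place of hydroxy on an aromatic carbon, the same change as between compound 1 and compound 2. Resting on the step of an at least 110-fold higher number from compound 1 to compound 2 (2.05 log units; beyond the scatter), compound 4 is expected to show a 130-fold higher number from compound 3 to compound 4 (2.12 log units; beyond the scatter). Compound 4 is therefore estimated at about 600000 nM, with a fair chance that only a limit is reported.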

Compound 4, half-maximal inhibitory concentration: 749000 nM
Estimate against measurement, compound 4: 1.2-fold (0.10 log units) below; low and high end bracket the measured number.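

The change carries over to the second core: in this assay, nitro in place of hydroxy gives a 160-fold higher number from compound 3 to compound 4 (2.21 log units; beyond the scatter), so inhibition is again much weaker. Both cores now show a large loss, but two cores do not make a rule for the whole series, and whether the loss has the same size on each stays unsettled: the same change on two cores in this assay, an at least 110-fold higher number (2.05 log units; beyond the scatter) from compound 1 to compound 2 and a 160-fold higher number (2.21 log units; beyond the scatter) from compound 3 to compound 4; the limit leaves it open whether they differ. Compound 2 stands at a limit of the assay, not at a number: the limit of > 3000000 nM in this assay, at which 1 of the 4 values shown sits.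

Only hydroxy and nitro are compared at this place on the ring. Going by these compounds, how an amine or a carboxylic acid there would compare with them remains open, on either core.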